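The source may hold more compounds than are shown below. What is called first, only, known or untested is meant among the compounds shown, and "the series" means these compounds.

Compound 2 `Oc1ccccc1-c1cc(-c2ccccc2O)nc(-c2ccccc2O)c1` gives 5040 nM in a functional assay on DU-145 cells (Homo sapiens) for cytotoxicity, read by CCK-8 assay, with a stated time of 4 days (on this read-out higher numbers stand for weaker inhibition and lower numbers for stronger inhibition), and compound 1 `Oc1cccc(-c2cc(-c3ccccc3O)nc(-c3ccccc3O)c2)c1` gives 5400 nM in this assay; the step of a 1.1-fold lower number from compound 1 to compound 2 (0.03 log units; within the scatter) shows the two sitting within the scatter of each other, so compound 2 stands alongside compound 1 rather than apart from it. Compound 3 `Oc1ccc(-c2cc(-c3ccccc3O)nc(-c3ccccc3O)c2)cc1` differs from compound 2 by 4-hydroxyphenyl in place of 2-hydroxyphenyl on an aromatic carbon. Within the data shown here, the only measured step that bears on this change is the one from compound 1 to compound 2, where moving the hydroxyl on the same aromatic carbon gave a 1.1-fold lower number from compound 1 to compound 2 (0.03 log units; within the scatter), a shift that did not exceed the scatter. Since a second relocation of the hydroxyl on that ring has no measured precedent beyond this, compound 3 is expected to show no step beyond the scatter in this assay, so that a 1.0-fold higher number from compound 2 to compound 3 (0.01 log units; within the scatter) is the estimate. Compound 3 is therefore expected to give 5200 nM, within a range from 2500 nM to 11000 nM.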

Compound 3, half-maximal inhibitory concentration: > 50000 nM
Compound 3 gave a limit, no number; the forecaster's own chance of this, stated with the estimate: 5%; at least 9.6-fold (0.98 log units) between middle value and limit.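

In this assay compound 3 reads > 50000 nM, which is a limit of the assay and not a number. The position opposite the ring nitrogen is therefore not indifferent to where the hydroxyl sits on the ring it carries: the 2-hydroxyphenyl and 3-hydroxyphenyl groups had stayed within the scatter of each other, whereas the 4-hydroxyphenyl group gives an at least 9.9-fold higher number from compound 2 to compound 3 (0.99 log units; beyond the scatter) and an at least 9.2-fold higher number from compound 1 to compound 3 (0.96 log units; beyond the scatter). This separation rests on a single reading that has no exact value: the limit of > 50000 nM in this assay, at which 1 of the 3 values shown sits.

From the compounds shown here alone, the true size of both steps stays open, as does any number for compound 3. Also open, going by these compounds, is whether an amine or a methoxy group in place of the hydroxyl on the 4-hydroxyphenyl group would read like compound 3 or like compound 2.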